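From (Pent-1-en-1-yl)carbonyl to (Azidomethyl)carbonyl

The source may report more compounds than this note shows. Statements on the series, on what has been measured and on what is new or still open speak of the compounds shown alone.

Measured so far:
compound 1 `CCC/C=C/C(=O)N(Cc1ccc(OC)c(O)c1)c1cc(OC)c(OC)c(OC)c1` — 70 nM
compound 3 `C/C=C/C(=O)N(Cc1ccc(OC)c(N)c1)c1cc(OC)c(OC)c(OC)c1` — 150 nM
compound 2 `COc1ccc(CNc2cc(OC)c(OC)c(OC)c2)cc1Br` — 29400 nM

Of the compounds shown here, three sharing one core have been tested in a functional assay on MGC-803 cells (Homo sapiens) for inhibition, read by MTT assay, with a stated time of 48 h; on this read-out lower numbers stand for stronger inhibition and higher numbers for weaker inhibition. Compound 1 gives 70 nM, the lowest number of the three. Its nearest neighbour is compound 3, which gives 150 nM, a gap that lies beyond the usual scatter of this assay. Compound 2 stands far from both: in this assay compound 2 gives 29400 nM, so among the three compounds measured, compound 1 stands alone as the most potent.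

The next compound, compound 4 `COc1ccc(CN(C(=O)CN=[N+]=[N-])c2cc(OC)c(OC)c(OC)c2)cc1O`, has not yet been measured. It differs from compound 1 in one place: azidomethyl in place of pent-1-en-1-yl on a carbonyl carbon. The carbonyl attached to the amide-type nitrogen is kept; only the group on that carbonyl carbon changes, the pent-1-en-1-yl of compound 1 giving way to azidomethyl.

Among the compounds with values here, no measured pair in this set isolates such a change, so the expectation rests on compound 1 alone, which gives 70 nM. Because compound 1 sits at 70 nM with the carbonyl on the nitrogen in place, compound 4 is expected to remain in the potent range while losing some ground, with an expected step of a 3.6-fold higher number from compound 1 to compound 4 (0.55 log units; beyond the scatter). Compound 4 is estimated at 250 nM, within a range of 60 nM to 1200 nM.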

Compound 4, half-maximal inhibitory concentration: 120 nM
The estimate for compound 4 lay 2.1-fold (0.32 log units) above the measured number; measured number inside the range.
By their numbers in this assay, from the lowest: compounds 1, 4 and 3 (each within the scatter of the next, the first and the last beyond it); then compound 2.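

In this assay, azidomethyl in place of pent-1-en-1-yl on the carbonyl carbon gives a 1.7-fold higher number from compound 1 to compound 4 (0.23 log units; within the scatter), a step within the usual scatter, so this read-out does not separate the two compounds. Within the data shown here, this is the first comparison in the set that isolates a change in one place, and it shows that the group on this carbonyl carbon can go from an all-carbon chain with one double bond to a group with three nitrogens and one hydrogen-bond acceptor with no difference that can be resolved here. Nothing in the available data bears on what lies behind this result.

Among these compounds, the single pair leaves open whether the same holds for other groups on this carbonyl carbon, such as an aminomethyl group, a carboxylic acid or a longer alkyl chain. The compounds shown also do not separate the contribution of the carbonyl itself from that of the rest of the structure, and they do not show whether azidomethyl would read the same alongside the amino group of compound 3.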